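Swapping a fluorophenyl for a hydroxycyclopentyl: toxicity outlook

The source may hold more compounds than are shown below. What is called first, only, known or untested is meant among the compounds shown, and "the series" means these compounds.

Among the measured compounds shown here, compound 3 `NC(=O)c1nc(C#Cc2cccc(F)c2)n(COCCO)n1` stands apart among the three measured compounds: in an ADME assay on Huh-5-2 cells (Homo sapiens) for cytotoxicity (on this read-out lower numbers stand for higher toxicity in this test and higher numbers for lower toxicity in this test), compound 3 gives 29 ug/mL, the only plain number in this set. Compound 1 `NC(=O)c1nc(C#Cc2ccccc2)n(COCCO)n1` reaches only a limit of the assay, giving > 50 ug/mL. Compound 2 `NC(=O)c1nc(C#Cc2ccc(F)cc2)n(COCCO)n1` likewise gives a limit, > 50 ug/mL. The measured steps are therefore an at least 1.7-fold lower number from compound 1 to compound 3 (0.23 log units; that floor lies within the scatter) and an at least 1.7-fold lower number from compound 2 to compound 3 (0.23 log units; that floor lies within the scatter), while a step that the two limits leave unreadable from compound 1 to compound 2.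

Compound 4 `NC(=O)c1nc(C#CC2(O)CCCC2)n(COCCO)n1` has not yet been measured. The change is 1-hydroxycyclopentyl in place of 3-fluorophenyl on a triple-bonded carbon. For the measured compounds named here, the steps that bear on it are an at least 1.7-fold lower number from compound 1 to compound 3 (0.23 log units; that floor lies within the scatter) and an at least 1.7-fold lower number from compound 2 to compound 3 (0.23 log units; that floor lies within the scatter); in both, the compound carrying the 3-fluorophenyl is the one that falls short of the limit of > 50 ug/mL in this assay, at which 2 of the 3 values shown sit. Removing that group is therefore expected to return the reading toward the limit, so the expected step is a 1.7-fold higher number from compound 3 to compound 4 (0.24 log units; within the scatter) in the direction of a higher number. Compound 4 is estimated at 50 ug/mL, with a range from 25 ug/mL to 100 ug/mL, and it is expected that the assay may again report only a limit.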

Compound 4, half-maximal cytotoxic concentration: > 50 ug/mL
Compound 4 ended at the assay's limit (the forecaster's own chance of this, stated with the estimate: 65%); the middle value sits exactly at the limit.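

In this assay, replacing 3-fluorophenyl with 1-hydroxycyclopentyl on the triple-bonded carbon gives an at least 1.7-fold higher number from compound 3 to compound 4 (0.23 log units; that floor lies within the scatter), so even this step's smallest possible size cannot be told apart from assay noise. The new information is that this position need not carry an aromatic ring for the reading to reach the limit: a five-membered non-aromatic ring with a hydroxyl group does so as well, as phenyl and 4-fluorophenyl did. Among the compounds shown here, the steps among compounds 1, 2 and 4 cannot be read, and compound 3 remains the only one with a plain number, leaving little room for ranking: the limit of > 50 ug/mL in this assay, at which 3 of the 4 values shown sit.

From the compounds shown here alone, how far compounds 1, 2 and 4 lie beyond that limit remains unknown. Going by these compounds, it also remains open whether an amine, a carboxylic acid or a longer carbon chain at this position would reach the limit too.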